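Swapping 2,4-difluorophenyl for 3,4-dimethoxyphenyl on the shared core

The compounds below may be only part of what the source reports. "The series", "measured", "known", "first", "only" and "open" are said of these compounds alone.

Compound 1 (`COc1cc(-n2c(-c3ccc(Cl)cc3)cn(C(C)=O)c2=O)cc(OC)c1OC`) has "not determined" (no result reported) as its entry in a functional assay on K-562R cells (Homo sapiens) for cytotoxicity, read by MTT assay, with a stated time of 48 h (a higher number here means a weaker inhibitor, a lower number a stronger inhibitor), and so offers no number. Compound 2 (`COc1cc(-n2c(-c3ccc(F)cc3F)cn(C(C)=O)c2=O)cc(OC)c1OC`) reads > 50000 nM in this assay and this is a limit of the assay, not a number. Compound 3 (`COc1ccc(-c2cn(C(C)=O)c(=O)n2-c2cc(OC)c(OC)c(OC)c2)cc1OC`) has 3,4-dimethoxyphenyl in place of 2,4-difluorophenyl on an aromatic carbon with the rest unchanged. For the measured compounds named here, no measured pair shows what such a swap does in this assay so the expectation is loose. The expected step is an at least 2.0-fold lower number from compound 2 to compound 3 (0.30 log units; that floor lies within the scatter) and it points modestly towards stronger inhibition. The estimated value for compound 3 is 25000 nM with an expected range from 3000 nM to 80000 nM in this test.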

Compound 3, half-maximal inhibitory concentration: > 50000 nM
Compound 3: only a limit was reported; the forecaster's own chance of this, stated with the estimate: 40%; middle value at least 2.0-fold (0.30 log units) from the limit.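

No step can be read from compound 2 to compound 3, because in this assay each gives only a limit and not a number: the limit of > 50000 nM in this assay, at which 2 of the 3 values shown sit.

The compounds shown leave open how 2,4-difluorophenyl and 3,4-dimethoxyphenyl compare on the shared core.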